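Carbonyl Group Added on the Aromatic Nitrogen of Compound 1

A few compounds are considered here, and "the series" means these few. Any claim that something is new, unique, unknown or untested is made for them only; others in the source may bear on it.

Compound 1 `Nc1ccc(C(=O)/C=C/c2ccc(Cl)cc2)cc1` stands highest of the two numbers recorded. In a functional assay on the whole organism (strain albino) for inhibition, with Rattus norvegicus as the target, read by paw edema, with stated times of 30 min and 3 h, at a dose of 100 mg/kg by the oral route (on this read-out lower numbers stand for less inhibition and higher numbers for more inhibition at the one dose given (going by the name of the read-out)), compound 1 gives 60%. The nearest compound is compound 2 `Nc1ccc(C(=O)/C=C/c2ccco2)cc1`, which in this assay gives 42%, a value beyond the scatter below that of compound 1. Among the measured compounds shown here, no step between these two has been computed, so their values are simply set side by side. Compound 3 `O=C(CBr)Nc1ccc(C(=O)/C=C/c2ccc(Cl)cc2)cc1` has not yet been measured in this assay. It differs from compound 1 by (bromomethyl)carbonyl in place of hydrogen on a nitrogen on an aromatic ring. For the measured compounds named here, no step of this kind among measured compounds is available, so its direction cannot be read from them. The step of a number 5 percentage points lower from compound 1 to compound 3 (within the scatter) is expected to be small, in either direction, and not clearly beyond the scatter. Compound 3 is therefore expected to give 55% in this assay, within a range from 35% to 75%.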

Compound 3, a percentage reported as inhibition, in the whole organism at one dose (the size of the read-out at that dose, not a potency): 59%
Beside the measured number, compound 3's estimate is 4 percentage points below it; the range from low to high includes it.
By their numbers in this assay, from the lowest: compound 2; then compounds 3 and 1 (each within the scatter of the next).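

In this assay, placing (bromomethyl)carbonyl in place of hydrogen on the nitrogen on an aromatic ring gives a number 1 percentage points lower from compound 1 to compound 3 (within the scatter), so the two values cannot be told apart. Among the compounds shown here, this is the first step read at this position, since the earlier pair differed elsewhere, and it shows that the hydrogen on this nitrogen can give way to this group with no change beyond the scatter at the one dose given. Nothing measured here explains this result.

The compounds shown leave open whether the bromine has any part in this, which an acetyl group or a longer chain on the same nitrogen would address. They also leave open whether the same change on the core of compound 2 would read the same way.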